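A few compounds are considered here, and "the series" means these few. Any claim that something is new, unique, unknown or untested is made for them only; others in the source may bear on it.

Measured in a functional assay on NCI-H460 cells (Homo sapiens) for inhibition, read by sulforhodamine B assay, with a stated time of 48 h; a lower number here means a stronger inhibitor of growth, a higher number a weaker inhibitor of growth:

compound 1, `COc1cc(-c2nn(-c3cccc(NC(=O)Nc4cc(C(F)(F)F)cc(C(F)(F)F)c4)c3)cc2-c2ccncc2)ccc1Cl`: 1870 nM
compound 2, `O=C(Nc1cccc(-n2cc(-c3ccncc3)c(-c3ccc(Cl)c(O)c3)n2)c1)Nc1cc(C(F)(F)F)cc(C(F)(F)F)c1`: 1480 nM
compound 3, `COc1cc(-c2nn(-c3cccc(NC(=O)Nc4ccc(Cl)c(C(F)(F)F)c4)c3)cc2-c2ccncc2)ccc1Cl`: 4790 nM

Compound 1 and compound 2 share everything except one point, where compound 2 carries hydrogen in place of methyl on an oxygen on an aromatic ring. This change moved the read-out only slightly, a 1.3-fold lower number from compound 1 to compound 2 (0.10 log units; within the scatter), so the two compounds are not separated by this assay. Compound 3 differs from compound 1 elsewhere in the molecule; the difference between the two cores is not broken down here. Compound 3 gives a higher number than compound 1 and than compound 2, and both of those gaps lie beyond the scatter, so compound 3 is the weakest of the three measured compounds in this assay.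

Compound 4, `O=C(Nc1cccc(-n2cc(-c3ccncc3)c(-c3ccc(Cl)c(O)c3)n2)c1)Nc1ccc(Cl)c(C(F)(F)F)c1`, is the counterpart of compound 3 in the same way that compound 2 is the counterpart of compound 1: it carries hydrogen in place of methyl on an oxygen on an aromatic ring, the same change at the same kind of place as seen from compound 1 to compound 2. Among the compounds with values here, the only guide to the size of this step is the single earlier occurrence, which stayed within the scatter. The step from compound 3 to compound 4 is therefore expected to be small as well, a 1.3-fold lower number from compound 3 to compound 4 (0.10 log units; within the scatter), resting on a 1.3-fold lower number from compound 1 to compound 2 (0.10 log units; within the scatter). With that, compound 4 is expected to give about 3800 nM in this assay, with a likely range from 1800 nM to 8000 nM, staying close to the value of compound 3 rather than approaching compound 1 or compound 2.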

Compound 4, concentration for total growth inhibition: 4000 nM
The estimate for compound 4 lay 1.1-fold (0.02 log units) below the measured number; the range from low to high includes it.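

In this assay, exchanging methoxy for hydroxy on the core of compound 3 gives a 1.2-fold lower number from compound 3 to compound 4 (0.08 log units; within the scatter), and the step set beside its earlier occurrence on the core of compound 1 shows no difference: the same change on two cores in this assay, a 1.3-fold lower number (0.10 log units; within the scatter) from compound 1 to compound 2 and a 1.2-fold lower number (0.08 log units; within the scatter) from compound 3 to compound 4, 1.1-fold (0.02 log units) apart, within the scatter of two such steps

For these two cores, the change from 4-chloro-3-methoxyphenyl to 4-chloro-3-hydroxyphenyl can therefore be carried across with the working expectation that the read-out will stay about where it was, and neither pair is separated by this measurement. This is a limited test of transfer, however: it rests on two pairs only, both steps are small, and nothing here shows how the change would behave on a core outside these two, in another cell line or under a different read-out, nor does it explain why the steps are small.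

The compounds shown leave open whether the place on the oxygen tolerates anything larger than methyl, such as a longer chain, and whether the read-out stays this flat when the hydroxy is replaced by an amine or a carboxylic acid. They also leave open whether any such replacement would move the read-out in this assay by more than the scatter on either core.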